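The source may report more compounds than this note shows. Statements on the series, on what has been measured and on what is new or still open speak of the compounds shown alone.

Measured so far in an ADME assay on HCT-116 cells (Homo sapiens) for cytotoxicity, read by CellTiter-Glo, with a stated time of 72 h; a lower number here means a stronger inhibitor, a higher number a weaker inhibitor:
compound 1 `CC1CCN(C2CCN(S(=O)(=O)c3cccnc3Cl)CC2)CC1`: > 10000 nM
compound 2 `CC1CCN(C2CCN(S(=O)(=O)c3cccc(N)c3)CC2)CC1`: > 5000 nM
compound 3 `COc1cccc(S(=O)(=O)N2CCC(N3CCC(C)CC3)CC2)c1`: > 5000 nM

All three entries are limits of the assay, not numbers. Compound 1 stands at the limit of > 10000 nM in this assay, at which 1 of the 3 values shown sits. Compound 3 stands with compound 2 at the limit of > 5000 nM in this assay, at which 2 of the 3 values shown sit. The position of compound 3 is therefore known only as a limit.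

Compound 4 `CCc1ccc(S(=O)(=O)N2CCC(N3CCC(C)CC3)CC2)cc1` carries 4-ethylphenyl in place of 3-methoxyphenyl on a sulfonyl sulfur.

For the measured compounds named here, three measured steps bear on this change, since each alters the group on that sulfur. They are a step that the two limits leave unreadable from compound 1 to compound 3, a step that the two limits leave unreadable from compound 2 to compound 3 and a step that the two limits leave unreadable from compound 1 to compound 2. None of them has a size that can be read. All three groups tried on the sulfur so far ended at a limit in this assay, and compound 4 is expected to follow them, most likely as a limit again. No step beyond the scatter is expected, and no direction can be given. The estimated step is a step that the limit leaves unreadable from compound 3 to compound 4.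

For compound 4 the estimated value is 8000 nM, with an expected range from 3000 nM to 20000 nM.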

Compound 4, half-maximal inhibitory concentration: > 5000 nM
Compound 4: no number, only a limit (the forecaster's own chance of this, stated with the estimate: 80%); the middle value does not contradict the limit.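

In this assay, for the compounds shown here, compound 4 gives > 5000 nM, a limit of the assay and not a number, so no step from compound 1, compound 2 or compound 3 to compound 4 can be read. The compounds shown leave open whether any group on the sulfonyl sulfur gives a measurable value in this assay.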